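Dichlorophenyl Swap on an Allyl-Bearing Core

The source may hold more compounds than are shown below. What is called first, only, known or untested is meant among the compounds shown, and "the series" means these compounds.

compound 1 `C=CCn1c(=O)/c(=C\c2cc(F)ccc2C)[nH]c(=O)/c1=C\c1ccccc1OC` — 2600 nM
compound 2 `COc1ccccc1/C=c1\c(=O)[nH]/c(=C/c2ccccc2Cl)c(=O)n1C` — 200 nM
compound 3 `COc1ccccc1/C=c1/[nH]c(=O)/c(=C\c2ccccc2OC)n(C)c1=O` — 16200 nM

In a functional assay on HL-60 cells (Homo sapiens) for cytotoxicity, read by CCK-8 assay, with a stated time of 72 h (a higher number here means a weaker inhibitor, a lower number a stronger inhibitor), compound 1 gives 2600 nM, the second highest of the three numbers; its nearest neighbor is compound 3 at 16200 nM, and the furthest is compound 2 at 200 nM, both gaps lying beyond the scatter. The unmeasured compound 4 `C=CCn1c(=O)/c(=C\c2cccc(Cl)c2Cl)[nH]c(=O)/c1=C\c1ccccc1OC` differs from compound 1 in a single place: 2,3-dichlorophenyl in place of 5-fluoro-2-methylphenyl on a double-bonded chain carbon bound to an aromatic carbon. Within the data shown here, no measured step exchanges a whole aryl group on this chain carbon. Among the measured compounds shown here, the one recorded step, an 81-fold higher number from compound 2 to compound 3 (1.91 log units; beyond the scatter), sits on the core carrying a methyl on nitrogen and replaces chloro by methoxy, which goes with a far weaker inhibitor. Among compounds 2 and 3, then, chloro on that aryl accompanies the stronger inhibitor. Compound 1 carries a fluoro-methyl pattern instead, and compounds 1 and 4 share an allyl-bearing core absent from compounds 2 and 3, so the transfer is uncertain. A moderate move toward a lower number, beyond the scatter, is nonetheless expected for the step, a 2.6-fold lower number from compound 1 to compound 4 (0.41 log units; beyond the scatter). Compound 4 is accordingly estimated at 1000 nM, within a range from 250 nM to 4000 nM.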

Compound 4, half-maximal inhibitory concentration: 2000 nM
Beside the measured number, compound 4's estimate is 2.0-fold (0.30 log units) below it; the range from low to high includes it.
By their numbers in this assay, from the lowest: compound 2; then compounds 4 and 1 (each within the scatter of the next); then compound 3.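

In this assay the exchange of 5-fluoro-2-methylphenyl for 2,3-dichlorophenyl on a double-bonded chain carbon bound to an aromatic carbon comes to a 1.3-fold lower number from compound 1 to compound 4 (0.11 log units; within the scatter) and so does not tell these two aryl groups apart on the allyl-bearing core. The earlier step of an 81-fold higher number from compound 2 to compound 3 (1.91 log units; beyond the scatter) had shown a large response to a change on this aryl group on the core carrying a methyl on nitrogen, whereas this pair shows that a whole-aryl exchange bringing in two chlorines need not move the number beyond the scatter. Chloro on this aryl group therefore does not go with a lower number in every setting shown, and nothing given here offers an explanation for this result.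

The compounds shown leave open whether an aryl group carrying an amine or a carboxylic acid on this chain carbon would move the number beyond the scatter on the allyl-bearing core. They also leave open how allyl and methyl on nitrogen compare, a question that needs a pair differing in that place alone.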